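This account rests on a few compounds, and the source may have more. Where it says the series, first, only, none or still open, it means among the compounds named here.

Compound 1 `COc1ccc(C(=O)/C=C/c2ccc(C(=O)N(C)c3ccccc3)cc2)c(O)c1` is the starting point. In an ADME assay on SH-SY5Y cells (Homo sapiens) for cytotoxicity, read by MTT assay, with a stated time of 48 h (on this read-out higher numbers stand for weaker inhibition and lower numbers for stronger inhibition), compound 1 reaches only the limit of the measurement, > 100000 nM, so no number is available for it. Compound 2 `CCOCCOc1cccc(/C=C/C(=O)c2ccc(OC)cc2O)c1` also sits at a limit in this assay, > 100000 nM. Compound 3 `CCOCCCOc1ccc(/C=C/C(=O)c2ccc(OC)cc2O)cc1OC` likewise gives a limit in this assay, > 100000 nM. All three measured compounds therefore share the same position, a limit (the limit of > 100000 nM in this assay, at which 3 of the 3 values shown sit), and nothing among them separates one from another. Compound 4 `COc1ccc(C(=O)/C=C/c2ccc(C(=O)Nc3ccccc3O)cc2)c(O)c1` differs from compound 1 in one place: (2-hydroxyphenyl)amino in place of methyl(phenyl)amino on a carbonyl carbon. With every measured value resting at the limit, a step from compound 1 to compound 4 is expected to be none beyond the scatter, a number no higher from compound 1 to compound 4 (the limit leaves the size open). Compound 4 is thus estimated at 100000 nM, within 30000 nM to 300000 nM, most likely again reported only as a limit.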

Compound 4, half-maximal inhibitory concentration: > 100000 nM
Compound 4: no number, only a limit; the forecaster's own chance of this, stated with the estimate: 85%; the middle value lies on the limit itself.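

Within the data shown here, compound 1 and compound 4 both give only a limit, so no step between them can be read: the limit of > 100000 nM in this assay, at which 4 of the 4 values shown sit. What stays open is whether swapping methyl(phenyl)amino for (2-hydroxyphenyl)amino changes anything in this assay, and at what concentration any compound shown would inhibit.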